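The compounds below may be only part of what the source reports. "The series", "measured", "known", "first", "only" and "open" are said of these compounds alone.

Compound 1 `C=CCOc1ccc2c(=O)c(-c3cc(OC)c(OC)cc3OC)coc2c1` is the starting point. Within the data shown here, in a functional assay on U-251 cells (Homo sapiens) for antiproliferative activity, read by MTT assay, with a stated time of 24 h (on this read-out higher numbers stand for weaker inhibition and lower numbers for stronger inhibition), compound 1 gives 5900 nM, and among the three measured compounds it is the only one that returns a number rather than a limit. Compound 2 `COc1cc(OC)c(-c2coc3cc(OCC(=O)c4cccc(C(F)(F)F)c4)ccc3c2=O)cc1OC` reaches only the limit of the assay, > 10000 nM. Compound 3 `COc1cc(OC)c(-c2coc3cc(OCc4ccccc4C(F)(F)F)ccc3c2=O)cc1OC` likewise reaches only the limit, > 10000 nM. Both comparisons that start from compound 1 therefore read as floors: an at least 1.6-fold higher number from compound 1 to compound 2 (0.22 log units; that floor lies within the scatter) and an at least 1.6-fold higher number from compound 1 to compound 3 (0.22 log units; that floor lies within the scatter), and the limit of > 10000 nM in this assay, at which 2 of the 3 values shown sit, sets the ceiling that hides their true size. The step between the two limit compounds is a step that the two limits leave unreadable from compound 2 to compound 3.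

Compound 4 `COc1cc(OC)c(-c2coc3cc(OCc4ccccc4Cl)ccc3c2=O)cc1OC` differs from compound 1 in one place: 2-chlorophenyl in place of vinyl on a saturated chain carbon bound to an oxygen on an aromatic ring. The closest measured step is the one in which 2-(trifluoromethyl)phenyl replaced vinyl at the same place, which pushed the number to the limit. Moving from compound 1 to compound 4 is therefore expected to weaken inhibition by a 2.0-fold higher number from compound 1 to compound 4 (0.31 log units; beyond the scatter), most likely landing again at the limit. Compound 4 is estimated at 12000 nM, within 4000 nM to 40000 nM.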

Compound 4, half-maximal inhibitory concentration: > 10000 nM
Compound 4: only a limit was reported; the forecaster's own chance of this, stated with the estimate: 60%; the middle value does not contradict the limit.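

In this assay, 2-chlorophenyl in place of vinyl gives an at least 1.6-fold higher number from compound 1 to compound 4 (0.22 log units; that floor lies within the scatter), a floor and not a measured size. Compound 4 shows that the limit is not tied to trifluoromethyl: with chloro on the aromatic ring instead, the read-out still returns no number, and compound 2, compound 3 and compound 4, all carrying a substituted phenyl group at this place, end alike at a limit. The steps among these three compounds cannot be read because of the ceiling of the assay: the limit of > 10000 nM in this assay, at which 3 of the 4 values shown sit.

Going by these compounds, how far any of them lies past the limit, and so whether any truly differs from compound 1, stays open. Also open, on these data alone, is how an amine or a carboxylic acid on a longer chain would read in place of the allyl group.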